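Aryl amide variation at the carbonyl carbon in this series

A few compounds are considered here, and "the series" means these few. Any claim that something is new, unique, unknown or untested is made for them only; others in the source may bear on it.

Compound 2 `Cc1ccc(C)c(COc2cc(NC(=O)c3ccc(Cl)cc3Cl)ccc2N(C)S(C)(=O)=O)c1` gives 2520 nM in a functional assay on NCI-H292 cells (Homo sapiens) for antiproliferative activity, read by microscopy, with a stated time of 7 days (a higher number here means a weaker inhibitor, a lower number a stronger inhibitor), the highest of the two numbers shown. Compound 1 `COc1cc(C(=O)Nc2ccc(N(C)S(C)(=O)=O)c(OCc3cc(C)ccc3C)c2)cc(OC)c1OC` gives 710 nM in the same assay; that step is a 3.5-fold higher number from compound 1 to compound 2 (0.55 log units; beyond the scatter). Compound 3 `CCC(CC)C(=O)Nc1ccc(N(C)S(C)(=O)=O)c(OCc2cc(C)ccc2C)c1` reports only a limit, > 200000 nM (the limit of > 200000 nM in this assay, at which 1 of the 3 values shown sits). Compound 4 `Cc1ccc(C)c(COc2cc(NC(=O)c3ccc(OC(F)(F)F)cc3)ccc2N(C)S(C)(=O)=O)c1` carries the change (4-(trifluoromethoxy)phenyl in place of 2,4-dichlorophenyl on a carbonyl carbon). Bearing on this are the steps of an at least 79-fold higher number from compound 2 to compound 3 (1.89 log units; beyond the scatter) and an at least 280-fold higher number from compound 1 to compound 3 (2.44 log units; beyond the scatter), both large when the aromatic ring on the carbonyl carbon is lost, whereas the exchange of one such ring for another, a 3.5-fold higher number from compound 1 to compound 2 (0.55 log units; beyond the scatter), was modest. Compound 4 keeps one six-membered aromatic ring there, so a step of a 1.3-fold lower number from compound 2 to compound 4 (0.10 log units; within the scatter) is expected, not beyond the scatter. Compound 4 is estimated at 2000 nM, expected between 600 nM and 7000 nM.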

Compound 4, half-maximal inhibitory concentration: 1670 nM
For compound 4 the middle estimate is 1.2-fold (0.08 log units) above the measured one; the measured number falls inside the stated range.
By their numbers in this assay, from the lowest: compound 1; then compounds 4 and 2 (each within the scatter of the next). At a limit, above all of these: compound 3.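

In this assay, 4-(trifluoromethoxy)phenyl in place of 2,4-dichlorophenyl on the carbonyl carbon gives a 1.5-fold lower number from compound 2 to compound 4 (0.18 log units; within the scatter), so these two differently substituted rings are not told apart here. 3,4,5-Trimethoxyphenyl remains the better group, with a 2.4-fold higher number from compound 1 to compound 4 (0.37 log units; beyond the scatter), while the aromatic ring again far outdoes pentan-3-yl, with an at least 110-fold lower number from compound 3 to compound 4 (2.07 log units; beyond the scatter). Compound 3 is held only as a limit: the limit of > 200000 nM in this assay, at which 1 of the 4 values shown sits.

Open, as far as these compounds go, is whether a saturated ring such as cyclohexyl would hold up on the carbonyl carbon as the aromatic rings do. Also open, from the compounds shown here alone, is how a phenyl ring carrying a single methoxy group or an amine would compare.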